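Moving the hydroxyl within the piperidine ring

The compounds below may be only part of what the source reports. "The series", "measured", "known", "first", "only" and "open" are said of these compounds alone.

Measured so far:
- compound 1 `CC(C)(C)c1ccc(C(=O)N2CCC3(CC2)C(=O)N(CC(=O)N2CCC(CCO)CC2)CN3c2ccccc2)cc1` gives 2600 nM in an assay on HEK293 cells for displacement of a labelled ligand from NPC1-like intracellular cholesterol transporter 1 (Homo sapiens); on this read-out lower numbers stand for stronger inhibition and higher numbers for weaker inhibition
- compound 2 `CC(C)(C)c1ccc(C(=O)N2CCC3(CC2)C(=O)N(CC(=O)N2CCCC(O)C2)CN3c2ccccc2)cc1` gives 12200 nM in this assay

Compound 2 stands at the highest of the two numbers measured; its nearest neighbour is compound 1, and the step of a 4.7-fold higher number from compound 1 to compound 2 (0.67 log units; beyond the scatter) is beyond the scatter, so compound 2 is the weaker of the two. The unmeasured compound 3 `CC(C)(C)c1ccc(C(=O)N2CCC3(CC2)C(=O)N(CC(=O)N2CCC(O)CC2)CN3c2ccccc2)cc1` keeps the shared core and differs from compound 2 only in the change (4-hydroxypiperidin-1-yl in place of 3-hydroxypiperidin-1-yl on a carbonyl carbon). For the measured compounds named here, only one measured step bears on this: the one from compound 1 to compound 2, in which a 4-(2-hydroxyethyl)piperidin-1-yl gave way to a 3-hydroxypiperidin-1-yl and the number rose by a 4.7-fold higher number from compound 1 to compound 2 (0.67 log units; beyond the scatter). Compound 3 carries its hydroxyl on a 4-hydroxypiperidin-1-yl, a group whose name places it nearer to compound 1 than to compound 2, so the expectation is a lower number than compound 2 but not as low as compound 1. The expected step is a 2.0-fold lower number from compound 2 to compound 3 (0.31 log units; beyond the scatter). Compound 3 is therefore estimated at 6000 nM in this assay, with a range from 2500 nM to 15000 nM.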

Compound 3, half-maximal inhibitory concentration: 4700 nM
For compound 3 the middle estimate is 1.3-fold (0.11 log units) above the measured one, and the stated range covers the measured number.
By their numbers in this assay, from the lowest: compounds 1 and 3 (each within the scatter of the next); then compound 2.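

In this assay, 4-hydroxypiperidin-1-yl in place of 3-hydroxypiperidin-1-yl gives a 2.6-fold lower number from compound 2 to compound 3 (0.41 log units; beyond the scatter), so where the hydroxyl sits on this ring matters, even though the two groups have the same atoms and the same counts of donors and acceptors. Hydroxy in place of 2-hydroxyethyl on a saturated ring carbon gives a 1.8-fold higher number from compound 1 to compound 3 (0.26 log units; within the scatter), so compound 1 and compound 3 cannot be told apart on this read-out, and the longer chain shows no measurable gain over a hydroxyl placed directly on the ring. The higher number of compound 2 therefore goes with the 3-hydroxypiperidin-1-yl group and not simply with losing the 2-hydroxyethyl chain. Nothing shown here explains why the place of the hydroxyl matters.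

On these data alone, whether this position needs a hydroxyl at all remains open, as a plain piperidin-1-yl, a 4-methoxypiperidin-1-yl, a 4-aminopiperidin-1-yl or a 4-carboxypiperidin-1-yl could each test that question. It is also unknown how a 3-(2-hydroxyethyl)piperidin-1-yl would compare, which would show whether the longer chain behaves differently when attached at the other ring carbon.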